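Two cores, one small ring change

A few compounds are considered here, and "the series" means these few. Any claim that something is new, unique, unknown or untested is made for them only; others in the source may bear on it.

Compound 1 `O=C1NC(=O)C(Cc2ccc(OCC3CCC3)cc2)S1` and compound 2 `O=C1NC(=O)/C(=C/c2ccc(OCC3CCC3)cc2)S1` both carry a cyclobutylmethoxy group; the difference between their two cores is not broken down here. In a functional assay on PC-12 cells (Rattus norvegicus) for inhibition, read by sulforhodamine B assay (a lower number here means a stronger inhibitor, a higher number a weaker inhibitor), compound 2 gives 13000 nM. For compound 1 the reading is a limit of the assay, > 100000 nM. Compound 3 `O=C1NC(=O)C(Cc2ccc(OCC3CC3)cc2)S1` differs from compound 1 by cyclopropyl in place of cyclobutyl on a saturated chain carbon bound to an oxygen on an aromatic ring. The reading for compound 3 is also a limit, > 100000 nM. The step that the two limits leave unreadable from compound 1 to compound 3 cannot be sized because of the limit of > 100000 nM in this assay, at which 2 of the 3 values shown sit. Compound 4 `O=C1NC(=O)/C(=C/c2ccc(OCC3CC3)cc2)S1` carries the same change on the core of compound 2, namely (cyclopropyl in place of cyclobutyl on a saturated chain carbon bound to an oxygen on an aromatic ring). Since compound 2 gives a real number, 13000 nM, a step of a 1.2-fold higher number from compound 2 to compound 4 (0.06 log units; within the scatter) is expected, resting on the small size of the ring change. Compound 4 is therefore estimated at 15000 nM, likely between 6000 nM and 40000 nM.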

Compound 4, half-maximal inhibitory concentration in the PC-12 assay: 23000 nM
Beside the measured number, compound 4's estimate is 1.5-fold (0.19 log units) below it; measured number inside the range.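

In the PC-12 assay compound 2 gives 13000 nM and compound 4 gives 23000 nM. On the core of compound 2, cyclopropyl in place of cyclobutyl reads in the PC-12 assay as a 1.8-fold higher number from compound 2 to compound 4 (0.25 log units; within the scatter), so the swap leaves no readable mark on this core. In a physicochemical assay for lipophilicity (on this read-out lower numbers stand for lower lipophilicity and higher numbers for higher lipophilicity), compound 2 gives 2.54 and compound 4 gives 1.99. In the physicochemical assay the same swap reads as a number 0.55 log units lower from compound 2 to compound 4 (beyond the scatter), a shift that does stand out from repeat measurements. Whether the result carries over from one core to the other cannot be judged, because the step from compound 1 to compound 3 cannot be read: the limit of > 100000 nM in the PC-12 assay, at which 2 of the 4 values shown sit.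

The compounds shown leave open how a cyclopentyl ring, a longer chain or an amine would read in the same place. They also leave open whether any such group would give the core of compound 1 a readable number.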